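Replacing Phenyl with a Sulfonamide Chain on the Piperidine

A few compounds are considered here, and "the series" means these few. Any claim that something is new, unique, unknown or untested is made for them only; others in the source may bear on it.

Compound 3, `COc1cc(COc2cc(N)c(Cl)cc2C(=O)CCCCN2CCC(c3ccccc3)CC2)cc(OC)c1`, holds the lower of the two numbered results in a functional assay for antagonist activity at 5-hydroxytryptamine receptor 4 (Rattus norvegicus) (a higher number here means a more potent compound, by a factor of ten per unit of this negative logarithm, a lower number a less potent compound), where compound 3 gives 7.7. Its nearest neighbour is compound 2, `COc1ccc(COc2cc(N)c(Cl)cc2C(=O)CCCCN2CCCCC2)cc1`, which in this assay gives 8.4, a result that lies above that of compound 3 by more than the usual scatter. Compound 1, `CCOc1cc(N)c(Cl)cc1C(=O)CCCCN1CCCCC1`, reaches in this assay only a limit, < 7, and not a number (the limit of < 7 in this assay, at which 1 of the 3 values shown sits). Among the measured compounds shown here, the single step measured between compounds that differ in one place is a number at least 1.40 log units higher from compound 1 to compound 2 (beyond the scatter); it concerns the group on the aromatic ether oxygen and is large.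

Compound 4, `COc1cc(COc2cc(N)c(Cl)cc2C(=O)CCCCN2CCC(CCNS(C)(=O)=O)CC2)cc(OC)c1`, differs from compound 3 in another region: 2-(methanesulfonamido)ethyl in place of phenyl on a saturated ring carbon. For the measured compounds named here, none of the measured compounds varies this position, and the step of a number at least 1.40 log units higher from compound 1 to compound 2 (beyond the scatter) changes a different part of the molecule, so the data give no direct guide for this exchange. In the absence of a comparable step, no change beyond the scatter is expected, though the uncertainty is wide. Compound 4 is therefore estimated to give 7.7 in this assay, with a range from 6.8 to 8.6. The expected step is no change at the digits printed from compound 3 to compound 4 (within the scatter).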

Compound 4, negative logarithm of the antagonist equilibrium constant: 8.1
Estimate against measurement, compound 4: 0.40 log units below; the measured number falls inside the stated range.
By their numbers in this assay, from the lowest: compound 3; then compounds 4 and 2 (each within the scatter of the next). At a limit, below all of these: compound 1.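

In this assay, the saturated ring carbon three ring bonds from the ring nitrogen proves open to a change of group: 2-(methanesulfonamido)ethyl in place of phenyl gives a number 0.40 log units higher from compound 3 to compound 4 (beyond the scatter) in a modest step. Among the compounds shown here, the earlier step concerned only the group on the aromatic ether oxygen, and this is the first reading at the piperidine position. It shows that, with the rest of compound 3 held constant, the six-membered aromatic ring of carbon only is not needed there, and that an open chain with no ring, carrying a hydrogen-bond donor and hydrogen-bond acceptors, can take its place with the number rising.

Going by these compounds, what remains open is which part of the new chain matters: a plain ethyl chain, an amine or a carboxylic acid at its end, or a longer chain would separate the length of the chain from the methanesulfonamide group. On these data alone, it is also open whether the same exchange would hold with the 4-methoxyphenyl group of compound 2 on the ether oxygen. Nothing in the data shown bears on why the number rises at this position.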